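Hydrazone aryl swap: methylphenyl to naphthyl in the series

The source may hold more compounds than are shown below. What is called first, only, known or untested is meant among the compounds shown, and "the series" means these compounds.

The shared core of compound 1 `CCCSc1nc(N/N=C(\C)c2ccc(OC)cc2)c2nnn(Cc3ccccc3)c2n1` carries an aryl hydrazone arm that is varied across the set. In a functional assay on ECa-109 cells (Homo sapiens) for antiproliferative activity, read by MTT assay, with a stated time of 72 h (on this read-out lower numbers stand for stronger inhibition and higher numbers for weaker inhibition), compound 1 reaches only the limit of the assay, > 64000 nM. Compound 2 `CCCSc1nc(N/N=C/c2ccc(C)cc2)c2nnn(Cc3ccccc3)c2n1` likewise returns only the limit in this assay, > 64000 nM. Among the compounds with values here, compound 3 `CCCSc1nc(N/N=C/c2cc(OC)c(OC)c(OC)c2)c2nnn(Cc3ccccc3)c2n1` is the one member with a number in this assay, 4060 nM. Compound 2 thus stands at the limit, and it is not alone there, because of the limit of > 64000 nM in this assay, at which 2 of the 3 values shown sit. Compound 4 `CCCSc1nc(N/N=C/c2ccc3ccccc3c2)c2nnn(Cc3ccccc3)c2n1` is not yet measured. It differs from compound 2 by naphthalen-2-yl in place of 4-methylphenyl on a carbon with a double bond to nitrogen. Within the data shown here, no step between measured compounds is available to rest on, and the two limits give no number from which a step could be read. Among the measured compounds shown here, the step from compound 2 to compound 4 is expected to be a moderate gain, an at least 2.1-fold lower number from compound 2 to compound 4 (0.32 log units; beyond the scatter), since the only numbered value in this assay comes from compound 3 at 4060 nM. Compound 4 is estimated at 30000 nM in this assay, in a range from 5000 nM to 120000 nM, with a fair chance that only the limit is returned.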

Compound 4, half-maximal inhibitory concentration: > 64000 nM
Compound 4 ended at the assay's limit (the forecaster's own chance of this, stated with the estimate: 45%); middle value at least 2.1-fold (0.32 log units) from the limit.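

Within the data shown here, compound 4 gives only a limit in this assay, > 64000 nM, and compound 2 also sits at a limit, so no step from compound 2 to compound 4 can be read. The compounds shown leave open whether naphthalen-2-yl in place of 4-methylphenyl changes antiproliferative activity at all.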